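A few compounds are considered here, and "the series" means these few. Any claim that something is new, unique, unknown or untested is made for them only; others in the source may bear on it.

Of the compounds shown here, two built on the same extended core have been tested in a functional assay on KB cells (Homo sapiens) for inhibition, read by sulforhodamine B assay; a higher number here means a weaker inhibitor of growth, a lower number a stronger inhibitor of growth. Compound 1 (`COc1cc(-c2ccc(-c3ccc(-c4nc5ccccc5[nH]4)cc3)cc2)cc(OC)c1OC`) gives 2980 nM, and compound 2 (`COc1ccc(-c2ccc(-c3ccc(-c4nc5c(O)cccc5[nH]4)cc3)cc2)cc1OC`) gives 2710 nM. Among the compounds with values here, these two values lie within the scatter of each other, so compound 2 stands level with the only other number available. Within the data shown here, the two compounds differ in more than one place, and no measured pair isolates a single change.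

Compound 3 (`COc1cc(-c2ccc(-c3ccc(-c4nc5c(O)cccc5[nH]4)cc3)cc2)cc(OC)c1OC`) follows from compound 2 with methoxy in place of hydrogen on an aromatic carbon, ortho to a methoxy group: methoxy in place of hydrogen on an aromatic carbon. This gives it the methoxy pattern of compound 1 while the rest of compound 2 stays unchanged. Since compound 1 at 2980 nM and compound 2 at 2710 nM sit level despite their differences, no clear shift in either direction is expected in this assay. The expected change, a 1.1-fold lower number from compound 2 to compound 3 (0.04 log units; within the scatter), is estimated to stay within the scatter. For compound 3 the estimated value is 2500 nM, with an expected range of 1000 nM to 6000 nM.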

Compound 3, concentration for 50% growth inhibition: 2110 nM
For compound 3 the middle estimate is 1.2-fold (0.07 log units) above the measured one; low and high end bracket the measured number.
By their numbers in this assay, from the lowest: compounds 3, 2 and 1 (each within the scatter of the next).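

In this assay, compound 3 allows two single changes to be read on their own, which compounds 1 and 2 alone did not allow. Methoxy in place of hydrogen on an aromatic carbon, ortho to a methoxy group and meta to a large group, gives a 1.3-fold lower number from compound 2 to compound 3 (0.11 log units; within the scatter), and the added hydroxy group gives a 1.4-fold lower number from compound 1 to compound 3 (0.15 log units; within the scatter), so neither single change takes the number beyond the scatter on this shared core. Nothing in the available data gives a reason for either result.

The compounds shown leave open whether another group at the methoxy position, such as an amine, a fluorine atom or a longer alkoxy chain, would take the number beyond the scatter in this assay. They also leave open whether a carboxylic acid or an amine in place of the hydroxy would do so, and whether either methoxy step would stay within the scatter on a compound that differs elsewhere in the core.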